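A few compounds are considered here, and "the series" means these few. Any claim that something is new, unique, unknown or untested is made for them only; others in the source may bear on it.

Within the data shown here, in a functional assay on SW480 cells (Homo sapiens) for inhibition, read by luminescence and resazurin assay, with a stated time of 3 days (a higher number here means a weaker inhibitor, a lower number a stronger inhibitor), compound 1 `CNc1nc(NCc2ccc(NS(=O)(=O)c3ccc(F)cc3)cc2)c2ccccc2n1` gives 4800 nM and compound 2 `CNc1nc(NCc2ccc(NC(=O)c3ccc(F)cc3)cc2)c2ccccc2n1` gives 2000 nM, the lower of the two numbers so far. Next comes compound 3 `CNc1nc(NCc2ccc(NS(=O)(=O)c3ccc(C)cc3)cc2)c2ccccc2n1`, which differs from compound 2 by (4-methylphenyl)sulfonyl in place of (4-fluorophenyl)carbonyl on a nitrogen on an aromatic ring. Among the measured compounds shown here, one measured step bears on this change, a 2.4-fold lower number from compound 1 to compound 2 (0.38 log units; beyond the scatter), modest but beyond the scatter, and the new change runs from carbonyl back to sulfonyl. For the measured compounds named here, no measured step covers 4-methylphenyl against 4-fluorophenyl, which widens the range without setting a direction. A step of similar size towards a higher number is therefore expected in this assay. The expected change is a 2.3-fold higher number from compound 2 to compound 3 (0.35 log units; beyond the scatter). For compound 3 the estimate is 4500 nM, with an expected range of 2000 nM to 10000 nM.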

Compound 3, half-maximal inhibitory concentration: 4900 nM
Compound 3: the middle estimate sits 1.1-fold (0.04 log units) below what was measured; the measured number falls inside the stated range.
By their numbers in this assay, from the lowest: compound 2; then compounds 1 and 3 (each within the scatter of the next).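

In this assay, among these compounds, the change on the nitrogen on an aromatic ring gives a 2.5-fold higher number from compound 2 to compound 3 (0.39 log units; beyond the scatter), the first step that combines a return to sulfonyl with a new ring substituent. Methyl in place of fluoro on an aromatic carbon gives a 1.0-fold higher number from compound 1 to compound 3 (0.01 log units; within the scatter), so within these sulfonyl compounds the substituent swap does not register, and among the three compounds the difference follows carbonyl against sulfonyl rather than methyl against fluoro. No measured evidence accounts for either step.

As far as these compounds go, it remains open whether methyl and fluoro also stay level when the nitrogen carries a carbonyl rather than a sulfonyl. Also open, from the compounds shown here alone, is whether a more different group on that ring, such as a carboxylic acid or an amine, moves the number.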